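The source may hold more compounds than are shown below. What is called first, only, known or untested is meant among the compounds shown, and "the series" means these compounds.

Measured so far:
compound 1 `COc1ncc(-c2ccccc2)cc1[C@@H](c1ccccc1)[C@@](O)(CCN(C)C)c1cc(F)ccc1F` — "nd" (no result reported)
compound 2 `COc1nc(-c2ccncc2)ccc1[C@@H](c1ccccc1)[C@@](O)(CCN(C)C)c1cccc2ccccc12` — 9.6 ug/mL

Compound 1 `COc1ncc(-c2ccccc2)cc1[C@@H](c1ccccc1)[C@@](O)(CCN(C)C)c1cc(F)ccc1F` was carried through the cell test without a result being reported, so it gives no number to lean on. Going by the values given here, in a toxicity assay on HeLa cells (Homo sapiens) for cytotoxicity (a lower number here means that less compound is tolerated, a higher number that more compound is tolerated), compound 2 gives 9.6 ug/mL, and this is the only number in the set; compound 2 therefore stands alone, with no other measured compound to place it above or below. Among the compounds with values here, since no second value is known, no measured step exists, and nothing can be said about how the read-out moves when part of compound 2 is exchanged.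

Compound 3 `COc1nc(-c2cnsc2)ccc1[C@@H](c1ccccc1)[C@@](O)(CCN(C)C)c1cccc2ccccc12` differs from compound 2 in a single place: 1,2-thiazol-4-yl in place of pyridin-4-yl on an aromatic carbon. One aromatic ring is swapped for another of similar size on the same aromatic carbon, while the rest of the molecule is unchanged. Within the data shown here, with no measured step to guide the direction, the expected step of a 1.0-fold lower number from compound 2 to compound 3 (0.00 log units; within the scatter) is one of no real size, none beyond the scatter. Compound 3 is accordingly expected to give about 9.5 ug/mL in this assay, within a range from 4.5 ug/mL to 20 ug/mL.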

Compound 3, half-maximal cytotoxic concentration: 28.8 ug/mL
Compound 3: middle estimate off by 3.0-fold (0.48 log units), on the low side; the measured number lies above the stated range.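

In this assay, going by these compounds alone, the exchange of pyridin-4-yl for 1,2-thiazol-4-yl gives a 3.0-fold higher number from compound 2 to compound 3 (0.48 log units; beyond the scatter) and is the first measured step in the set. It shows that the read-out at this position, on an aromatic carbon next to the ring nitrogen and para to a large group, depends on which aromatic ring sits there: more compound is tolerated with the five-membered ring carrying two hetero atoms than with the six-membered ring carrying one. Nothing in the available data accounts for this step.

The step changes ring size and the number of hetero atoms together, so the compounds shown leave open whether either change alone would move the number, and this single pair cannot show whether the same exchange would have a similar effect elsewhere in the series. They also leave open how the read-out would respond to a phenyl ring, a simple amine or a carboxylic acid on this same aromatic carbon.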